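The source may hold more compounds than are shown below. What is called first, only, known or untested is meant among the compounds shown, and "the series" means these compounds.

Measured compounds:
compound 1, `Cc1cccc(-c2noc(C(C)NC(=O)c3cc(C4CC4)nn3C)n2)c1`, giving 1880 nM in an assay on T-REx-293 cells for inhibition of potassium channel subfamily T member 1 (Homo sapiens), read by patch clamp; a lower number here means a stronger inhibitor, a higher number a weaker inhibitor
compound 2, `Cc1cccc(-c2noc([C@H](C)NC(=O)c3cc(C4CC4)nn3C)n2)c1`, giving 167 nM in this assay
compound 3, `Cc1cccc(-c2noc([C@@H](C)NC(=O)c3cc(C4CC4)nn3C)n2)c1`, giving 3310 nM in this assay

Compound 2 stands lowest of the three numbers in this assay. Its nearest neighbour is reached by an 11-fold lower number from compound 1 to compound 2 (1.05 log units; beyond the scatter), its furthest by a 20-fold higher number from compound 2 to compound 3 (1.30 log units; beyond the scatter). The step of a 1.8-fold higher number from compound 1 to compound 3 (0.25 log units; within the scatter) is small. These three steps all turn on configuration alone, which is shown by the fact that one of compounds 1 and 2 is drawn with a defined configuration and the other without, at the place where they differ, the fact that one of compounds 1 and 3 is drawn with a defined configuration and the other without, at the place where they differ and (the fact that compounds 2 and 3 differ only in the configuration as drawn).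

Compound 4, `C[C@H](NC(=O)c1cc(C2CC2)nn1C)c1nc(-c2ccccc2)no1`, is not yet measured. It differs from compound 2 in one place: hydrogen in place of methyl on an aromatic carbon. Within the data shown here, none of the measured steps touches this place; they concern only the drawn configuration at the saturated chain carbon, which compound 4 keeps the same as compound 2. Among the measured compounds shown here, there is therefore no measured step from which the size or direction of the change in this assay can be read, and the expectation rests on the change being a small one on the periphery of the shared core.

Compound 4 is expected to give 350 nM in this assay, within 90 nM to 1400 nM. This corresponds to an expected 2.1-fold higher number from compound 2 to compound 4 (0.32 log units; beyond the scatter), which may well fall within the scatter.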

Compound 4, half-maximal inhibitory concentration: 11400 nM
Compound 4: the middle estimate sits 33-fold (1.51 log units) below what was measured; the whole stated range lies below it.
By their numbers in this assay, from the lowest: compound 2; then compounds 1 and 3 (each within the scatter of the next); then compound 4.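

In this assay, among these compounds, taking the single methyl off the six-membered aromatic ring gives a 68-fold higher number from compound 2 to compound 4 (1.83 log units; beyond the scatter), so the 3-methylphenyl to phenyl change is a large one at a position that none of the earlier steps touched. Until now the compounds had shown only that the drawn configuration at the saturated chain carbon counts, with a 20-fold higher number from compound 2 to compound 3 (1.30 log units; beyond the scatter); compound 4 keeps the configuration of compound 2, so this new step shows that one carbon on the aromatic ring also counts heavily in this series. None of the observations at hand bears on this change, and nothing shown accounts for its size.

Only hydrogen and methyl are shown at this place, so it stays open whether a chlorine, a methoxy group or an ethyl group would keep the number of compound 2, lower it or raise it. Also open, going by these compounds, is whether the methyl counts as much with the opposite configuration at the saturated chain carbon, as drawn in compound 3, which gives 3310 nM.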